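The source may report more compounds than this note shows. Statements on the series, on what has been measured and on what is new or still open speak of the compounds shown alone.

Measured in a functional assay on the whole organism (strain albino) for inhibition, with Rattus norvegicus as the target, read by paw edema, with stated times of 30 min and 3 h, at a dose of 100 mg/kg by the oral route; on this read-out higher numbers stand for more inhibition at the one dose given (going by the name of the read-out) and lower numbers for less inhibition:
compound 1 `COc1ccc(C2=NN(C(=O)CBr)C(c3c(Cl)cccc3Cl)C2)cc1` gives 7%
compound 2 `COc1ccc(C2=NN(C(=O)CO[N+](=O)[O-])C(c3c(Cl)cccc3Cl)C2)cc1OC` gives 58%

Going by the values given here, compound 2 stands highest of the two numbers; compound 1 is its only neighbour, and the gap between them lies beyond the usual scatter. Among the compounds with values here, compound 1 and compound 2 differ in more than one place, so no single step is defined between them; their two values show only that the combined difference separates a low from a clearly higher paw edema read-out.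

Compound 3 `COc1ccc(C2=NN(C(=O)CO[N+](=O)[O-])C(c3c(Cl)cccc3Cl)C2)cc1` differs from compound 2 in one place: hydrogen in place of methoxy on an aromatic carbon. Within the data shown here, no measured pair isolates this change, so its weight cannot be read directly from the data. Compound 1 is low but is not a clean comparator for it. The step in this assay from compound 2 to compound 3 is expected to be downward and beyond the scatter, a number 20 percentage points lower from compound 2 to compound 3 (beyond the scatter), yet not to the floor. For compound 3 the expected value is 38%, in the range 15% to 58%.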

Compound 3, a percentage reported as inhibition, in the whole organism at one dose (the size of the read-out at that dose, not a potency): 52%
Estimate against measurement, compound 3: 14 percentage points below; the range from low to high includes it.
By their numbers in this assay, from the lowest: compound 1; then compounds 3 and 2 (each within the scatter of the next).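

In this assay, hydrogen in place of methoxy on the aromatic carbon, the change from 3,4-dimethoxyphenyl to 4-methoxyphenyl, gives a number 6 percentage points lower from compound 2 to compound 3 (within the scatter) and so leaves the read-out unresolved from that of the dimethoxy compound at this dose. The pair of compound 1 and compound 3 now isolates a single change on the saturated chain carbon bound to a carbonyl carbon: nitrooxy in place of bromo gives a number 45 percentage points higher from compound 1 to compound 3 (beyond the scatter), a step far larger than the one at the aromatic position. No measured property bears on the size of either step.

Going by these compounds, whether a hydroxy group, an amine or a longer alkoxy chain on the same aromatic carbon would also leave the read-out in place stays open. On these data alone, on the chain carbon, it is equally open how a hydroxy group or a carboxylic acid would compare with nitrooxy and bromo.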